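A few compounds are considered here, and "the series" means these few. Any claim that something is new, unique, unknown or untested is made for them only; others in the source may bear on it.

Measured so far:
Compound 1 `OCCn1cc2c(Nc3ccc(OC(F)(F)F)cc3)ncnc2n1` gives > 10000 nM in an ADME assay on BaF3 cells (Mus musculus) for cytotoxicity; on this read-out higher numbers stand for an effect only at larger amounts of compound and lower numbers for an effect already at smaller amounts; this is a limit of the assay, not a number.
Compound 2 `OCCn1ncc2c(Nc3ccc(OC(F)(F)F)cc3)ncnc21` gives > 10000 nM in this assay; again a limit of the assay.

Within the data shown here, compound 1 therefore stands at the limit of > 10000 nM in this assay, at which 2 of the 2 values shown sit, and no step between measured compounds can be read. Compound 3 `FC(F)(F)Oc1ccc(Nc2ncnc3nn(Cc4ccccc4)cc23)cc1` differs from compound 1 by phenyl in place of hydroxymethyl on a saturated chain carbon bound to an aromatic nitrogen. Without a measured step in this direction, the expected step in this assay is a step that the limit leaves unreadable from compound 1 to compound 3, none beyond the scatter. Compound 3 is expected to give 12000 nM in this assay, within 3000 nM to 40000 nM, most likely reported again only as a limit.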

Compound 3, half-maximal effective concentration: > 10000 nM
Compound 3 gave a limit, no number; the forecaster's own chance of this, stated with the estimate: 70%; the middle value does not contradict the limit.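

Compound 1 and compound 3 both give only a limit in this assay, so no step can be read for 2-hydroxyethyl to benzyl: the limit of > 10000 nM in this assay, at which 3 of the 3 values shown sit. The compounds shown leave open at what concentration any of them affects these cells.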